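The source may report more compounds than this note shows. Statements on the series, on what has been measured and on what is new or still open speak of the compounds shown alone.

Measured in an ADME assay on the whole organism (plasma) for pharmacokinetics, with Rattus norvegicus as the target, with a stated time of 6 h, at a dose of 10 mg/kg by the oral route; on this read-out higher numbers stand for higher exposure at the dose given and lower numbers for lower exposure:
Compound 1, `CCNc1nc(C)c(-c2nc3ccccc3s2)c(N[C@@H]2C[C@H](CO)[C@@H](O)[C@H]2O)n1`, gives 2580 ng.h/mL.
Compound 2, `Cc1nc(NC(C)(C)C)nc(N[C@@H]2C[C@H](CO)[C@@H](O)[C@H]2O)c1-c1nc2ccccc2s1`, gives 2220 ng.h/mL.
Compound 3, `Cc1nc(NCc2ccccn2)nc(N[C@@H]2C[C@H](CO)[C@@H](O)[C@H]2O)c1-c1nc2ccccc2s1`, gives 1630 ng.h/mL.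

The three numbers sit close together. The step of a 1.6-fold lower number from compound 1 to compound 3 (0.20 log units; within the scatter) and the step of a 1.4-fold lower number from compound 2 to compound 3 (0.13 log units; within the scatter) both lie within the scatter, as does the step of a 1.2-fold lower number from compound 1 to compound 2 (0.07 log units; within the scatter), so compound 3 is not set apart from compound 1 or compound 2 on this read-out.

Compound 4, `Cc1nc(NCc2ccncc2)nc(N[C@@H]2C[C@H](CO)[C@@H](O)[C@H]2O)c1-c1nc2ccccc2s1`, differs from compound 3 in one place: pyridin-4-yl in place of pyridin-2-yl on a saturated chain carbon bound to a nitrogen on an aromatic ring. Among the measured compounds shown here, no measured step exchanges one pyridyl for another, so none bears on this change directly. The steps that touch the same place, the step of a 1.6-fold lower number from compound 1 to compound 3 (0.20 log units; within the scatter) and the step of a 1.4-fold lower number from compound 2 to compound 3 (0.13 log units; within the scatter), show that quite different groups on that nitrogen left this assay within the scatter. On that basis the step of a 1.0-fold lower number from compound 3 to compound 4 (0.01 log units; within the scatter) is expected to stay within the scatter, with no clear direction. Compound 4 is therefore estimated at 1600 ng.h/mL, with a range from 750 ng.h/mL to 3400 ng.h/mL.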

Compound 4, area under the concentration-time curve: 47.9 ng.h/mL
Beside the measured number, compound 4's estimate is 33-fold (1.52 log units) above it, outside the stated range (below it).
By their numbers in this assay, from the lowest: compound 4; then compounds 3, 2 and 1 (each within the scatter of the next).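

In this assay, ethyl, tert-butyl and (pyridin-2-yl)methyl on the nitrogen on an aromatic ring had given numbers within the scatter of one another, but this position proves sensitive to a change that leaves the atoms the same and only joins them differently, with a 34-fold lower number from compound 3 to compound 4 (1.53 log units; beyond the scatter). The same gap appears against the two simpler groups, with a 46-fold lower number from compound 2 to compound 4 (1.67 log units; beyond the scatter) and a 54-fold lower number from compound 1 to compound 4 (1.73 log units; beyond the scatter), so among these four compounds (pyridin-4-yl)methyl alone stands apart. Nothing available here bears on why this exchange of pyridyl groups has so large an effect on exposure.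

The compounds shown leave open whether pyridin-3-yl on that saturated chain carbon would stay with the pyridin-2-yl group or fall with the pyridin-4-yl group. They also leave open where a plain phenyl ring in the same place would stand.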